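Cytotoxicity at the assay limit: from compound 1 to compound 3

The compounds below may be only part of what the source reports. "The series", "measured", "known", "first", "only" and "open" are said of these compounds alone.

compound 1 `CSc1ccccc1SCO[C@H]1C[C@H](n2cc(C)c(=O)[nH]c2=O)O[C@@H]1CO`: > 100000 nM
compound 2 `CSc1ccccc1SCO[C@H]1C[C@H](n2cnc3c(O)nc(N)nc32)O[C@@H]1CO`: > 100000 nM

In an ADME assay on cells (Bos taurus) for cytotoxicity (a higher number here means that more compound is tolerated, a lower number that less compound is tolerated), compound 1 gives > 100000 nM, which is a limit of the assay and not a number. Compound 2 gives > 100000 nM, which is also a limit. So the data so far consist of the limit of > 100000 nM in this assay, at which 2 of the 2 values shown sit. Neither compound therefore has an exact value, and compound 1 stands at the limit rather than at a known concentration.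

Compound 3 `CSc1ccccc1SCO[C@H]1C[C@H](n2ccc(N)nc2=O)O[C@@H]1CO` keeps the rest of compound 1 and changes one group, on a saturated ring carbon of a five-membered non-aromatic ring with 1 oxygen: a group of 8 heavy atoms (4 carbon, 3 nitrogen, 1 oxygen; one six-membered aromatic ring with 2 hetero atoms) in place of a group of 9 heavy atoms (5 carbon, 2 nitrogen, 2 oxygen; one six-membered aromatic ring with 2 hetero atoms), on a saturated ring carbon.

For the measured compounds named here, no measured pair shows the effect of a single change here, so any forecast rests on little. Compound 1 and compound 2 carry different groups at this place, yet both sit at the limit. No step beyond the scatter is expected in this assay, in either direction. The estimated change a number no higher from compound 1 to compound 3 (the limit leaves the size open) is correspondingly small, and the assay will probably report only a limit again. For compound 3 the expected value is 100000 nM, with an estimated range of 50000 nM to 200000 nM.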

Compound 3, half-maximal cytotoxic concentration: > 100000 nM
Compound 3: a limit, no number; the forecaster's own chance of this, stated with the estimate: 85%; the middle value lies on the limit itself.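

In this assay compound 3 gives > 100000 nM as a limit of the assay and not a number. For the compounds shown here, compound 1 also has only a limit, so no step from compound 1 to compound 3 can be read, and all the data share one limit: the limit of > 100000 nM in this assay, at which 3 of the 3 values shown sit. How much of any of these compounds the cells would tolerate remains open, as does whether changing the group on the saturated ring carbon affects that.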